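Extending the Side Chain of Compound 2

A few compounds are considered here, and "the series" means these few. Any claim that something is new, unique, unknown or untested is made for them only; others in the source may bear on it.

Measured compounds:
Compound 1 `CCCCCCC1(O)C(=O)Nc2ccc(Nc3ccc(OC)cc3)cc21`: 18600 nM
Compound 2 `CC(C)CCC1(O)C(=O)Nc2ccc(Nc3ccc(Cl)cc3)cc21`: 2700 nM

In a functional assay on A549 cells (Homo sapiens) for antiproliferative activity, read by MTT assay, with a stated time of 48 h (on this read-out lower numbers stand for stronger inhibition and higher numbers for weaker inhibition), compound 2 has the lower of the two numbers, and so the stronger inhibition. Its gap to compound 1 lies beyond the scatter. Compound 3 `CCCCCCC1(O)C(=O)Nc2ccc(Nc3ccc(Cl)cc3)cc21` comes from compound 2 by a single change: butyl in place of isopropyl on a saturated chain carbon, two bonds along the chain from a saturated ring carbon. Cut one bond further out, the same difference reads as isopentyl to hexyl. Among the measured compounds shown here, no two measured compounds differ in one place only, so the data show no direct precedent for this change. A small upward step within the scatter is therefore expected in this assay, and the expected step is a 1.2-fold higher number from compound 2 to compound 3 (0.07 log units; within the scatter). For compound 3 the estimated value is 3200 nM, with an expected range of 1300 nM to 8000 nM.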

Compound 3, half-maximal inhibitory concentration: 5400 nM
The estimate for compound 3 lay 1.7-fold (0.23 log units) below the measured number; low and high end bracket the measured number.
By their numbers in this assay, from the lowest: compounds 2 and 3 (each within the scatter of the next); then compound 1.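

In this assay, butyl in place of isopropyl on a saturated chain carbon, two bonds along the chain from a saturated ring carbon, gives a 2.0-fold higher number from compound 2 to compound 3 (0.30 log units; within the scatter), so this position tolerates the change from the branched to the straight chain without a step beyond the scatter. Chloro in place of methoxy on an aromatic carbon gives a 3.4-fold lower number from compound 1 to compound 3 (0.54 log units; beyond the scatter), a step beyond the scatter that compounds 1 and 2 alone could not show, as they differ in two places. Nothing measured here bears on why either step has this size.

On these data alone, it remains open whether a longer chain or a chain ending in an amine or a carboxylic acid would move the number beyond the scatter at this position. As far as these compounds go, whether bromo or trifluoromethyl on the same aromatic carbon would match chloro also remains open.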